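Replacing phenyl with 1-methyl-1H-pyrazol-4-yl

A few compounds are considered here, and "the series" means these few. Any claim that something is new, unique, unknown or untested is made for them only; others in the source may bear on it.

Compound 2 `O=c1nc(-c2ccccc2)c2cc(-c3ccccc3)ccc2[nH]1` gives > 50000 nM in an ADME assay on L6 cells (Rattus norvegicus) for cytotoxicity, read by fluorescence and resazurin assay, with a stated time of 72 h (a higher number here means that more compound is needed for the effect, a lower number that less compound is needed), and this is a limit, not a number. Compound 3 `CNC(=O)c1cccc(-c2ccc3[nH]c(=O)nc(-c4ccccc4)c3c2)c1` gives > 50000 nM and this too is a limit. Compound 1 `CN(C)c1ccc(-c2ccc3[nH]c(=O)nc(-c4ccccc4)c3c2)cn1` gives 50000 nM as a number. The series therefore stands at the limit of > 50000 nM in this assay, at which 2 of the 3 values shown sit, with no lower reading shown.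

Compound 4 `Cn1cc(-c2ccc3[nH]c(=O)nc(-c4ccccc4)c3c2)cn1` differs from compound 2 by 1-methyl-1H-pyrazol-4-yl in place of phenyl on an aromatic carbon and so carries 1-methyl-1H-pyrazol-4-yl in place of phenyl on an aromatic carbon. For the measured compounds named here, the one measured step on compound 2 is a step that the two limits leave unreadable from compound 2 to compound 3 and it offers no size to carry over. No change beyond the scatter is expected in this assay in either direction, and the expected at least 1.1-fold lower number from compound 2 to compound 4 (0.04 log units; that floor lies within the scatter) stays small. The estimated value for compound 4 is 45000 nM with an expected range from 15000 nM to 60000 nM in this read-out.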

Compound 4, half-maximal effective concentration: > 50000 nM
Compound 4 ended at the assay's limit; the forecaster's own chance of this, stated with the estimate: 70%; middle value at least 1.1-fold (0.04 log units) from the limit.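

In this assay compound 4 gives > 50000 nM, a limit and not a number. For the compounds shown here, compound 2 gives > 50000 nM, also a limit, so no step between compound 2 and compound 4 can be read. The compounds shown leave open what concentration compound 2 or compound 4 would need for the half-maximal effect.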